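The source may hold more compounds than are shown below. What is called first, only, known or untested is meant among the compounds shown, and "the series" means these compounds.

Measured compounds:
Compound 1, `COc1ccc(/C=C/C(=O)c2ccc(O)cc2)cc1Br`, in an assay on isolated protein for inhibition of DNA topoisomerase 1 (Homo sapiens), tested at 100 uM (on this read-out higher numbers stand for a stronger effect at the one concentration tested and lower numbers for a weaker effect), gives 24.8%.
Compound 2, `COc1ccc(C(=O)/C=C/c2ccc(OC)c(Br)c2)c(O)c1`, in this assay gives 5%.

Compound 2 stands at the lowest of the two numbers, and the gap to compound 1 is beyond the usual scatter, so compound 2 is the weaker of the pair on this read-out. The unmeasured compound 3, `COc1ccc(/C=C/C(=O)c2ccc(O)cc2O)cc1Br`, is reached from compound 2 by a single change: hydrogen in place of methyl on an oxygen on an aromatic ring. Going by the values given here, no comparable step between measured compounds is available, so the expectation rests only on the two values shown. Compound 1 carries a hydroxy on its shared core and gives the higher number, which is a weak hint that compound 3 could move upward, though a change of no more than the scatter is just as plausible. Compound 3 is therefore expected to give about 12%, with a likely range from 0% to 30%, an estimated step of a number 7 percentage points higher from compound 2 to compound 3 (within the scatter).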

Compound 3, a percentage reported as inhibition, at one concentration (the size of the read-out at that concentration, not a potency): 73.2%
Compound 3: middle estimate off by 61.2 percentage points, on the low side, and the stated range ends below it.
By their numbers in this assay, from the lowest: compound 2; then compound 1; then compound 3.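

Hydrogen in place of methyl on an oxygen on an aromatic ring gives a number 68.2 percentage points higher from compound 2 to compound 3 (beyond the scatter) in this assay and shows that a change of a single methyl at this place can go with a large shift in the read-out. Hydroxy in place of hydrogen on an aromatic carbon gives a number 48.4 percentage points higher from compound 1 to compound 3 (beyond the scatter) on the same read-out, so at this place the hydroxy stands above both the methoxy and the bare hydrogen. Nothing available explains why this small change goes with so large a shift.

The compounds shown leave open whether another group at this place, such as an amine, a carboxylic acid or a longer chain on the oxygen, would keep the higher number. They also leave open how compound 3 would behave at any other concentration, since the reading shows only the size of its effect at the one concentration tested.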